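Removing the Central Methoxy Group from Compound 1

The source may report more compounds than this note shows. Statements on the series, on what has been measured and on what is new or still open speak of the compounds shown alone.

Compound 1 `COc1cc(-n2cc(-c3ccc(N)cc3)nn2)cc(OC)c1OC` was tested in a functional assay on MDA-MB-231 cells (Homo sapiens) for cytotoxicity, read by MTT assay; a higher number here means a weaker inhibitor, a lower number a stronger inhibitor. In this assay compound 1 gives only a limit, > 10000 nM. Compound 2 `COc1cc(-n2cc(-c3cc(O)cc(O)c3)nn2)cc(OC)c1OC` gives a limit as well, > 10000 nM. Compound 3 `COc1ccc(-n2cc(-c3ccc(N)cc3)nn2)cc1OC` likewise gives a limit, > 10000 nM. All three values rest at the same limit, as the limit of > 10000 nM in this assay, at which 3 of the 3 values shown sit, records, so the step that the two limits leave unreadable from compound 1 to compound 2 and the step that the two limits leave unreadable from compound 1 to compound 3 cannot be sized. Compound 4 `COc1cc(OC)cc(-n2cc(-c3ccc(N)cc3)nn2)c1` differs from compound 1 by the change (hydrogen in place of methoxy on an aromatic carbon). Within the data shown here, the step from compound 1 to compound 3, another methoxy removed, is the nearest measured parallel, yet it yields no readable size, so no measured step supports a change beyond the scatter. Compound 4 is expected most likely to return a limit again. The estimate for compound 4 is 20000 nM, with a range from 7000 nM to 100000 nM. The expected step that the limit leaves unreadable from compound 1 to compound 4 is therefore essentially none.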

Compound 4, half-maximal inhibitory concentration: > 10000 nM
Compound 4: no number, only a limit; the forecaster's own chance of this, stated with the estimate: 85%; the middle value is on the limit's open side.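

Compound 1 and compound 4 both give only a limit, so no size can be read for the step between them: the limit of > 10000 nM in this assay, at which 4 of the 4 values shown sit.

The compounds shown leave open whether swapping methoxy for hydrogen changes cytotoxicity at all, since none of them gives a readable number.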